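Chlorophenyl to Benzyl: What to Expect for Compound 4

The source may report more compounds than this note shows. Statements on the series, on what has been measured and on what is new or still open speak of the compounds shown alone.

Measured in an assay on microsomes from brain for inhibition of Fatty-acid amide hydrolase 1 (Rattus norvegicus), read by fluorescence and HPLC, with a stated time of 60 min; a higher number here means a weaker inhibitor, a lower number a stronger inhibitor:
compound 1 `CCCCCCCCc1ccc(OCC(=O)Cn2nnc(-c3ccncc3)n2)cc1` gives 24 nM
compound 2 `CCCCCCCCc1ccc(OCC(=O)Cn2nnc(C(=O)OC)n2)cc1` gives 88 nM
compound 3 `CCCCCCCCc1ccc(OCC(=O)Cn2nnnc2-c2ccccc2Cl)cc1` gives 4600 nM

Compound 3 has the highest number of the three and is therefore the weakest inhibitor among them. Compound 4 `CCCCCCCCc1ccc(OCC(=O)Cn2nnnc2Cc2ccccc2)cc1` differs from it in one place: benzyl in place of 2-chlorophenyl on an aromatic carbon. Going by the values given here, the only measured step, a 3.7-fold higher number from compound 1 to compound 2 (0.56 log units; beyond the scatter), concerns a different group on a different carbon of the shared core, so it says nothing about this change. Among the compounds with values here, no measured compound carries a benzyl group, so the size and direction of the step are unknown. The estimate for compound 4 is therefore set close to compound 3 with a wide range: the number expected for compound 4 is 3000 nM, somewhere between 600 nM and 15000 nM. This corresponds to an expected step of a 1.5-fold lower number from compound 3 to compound 4 (0.19 log units; within the scatter).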

Compound 4, half-maximal inhibitory concentration: 320 nM
Beside the measured number, compound 4's estimate is 9.4-fold (0.97 log units) above it; the whole stated range lies above it.
By their numbers in this assay, from the lowest: compound 1; then compound 2; then compound 4; then compound 3.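

In this assay the change from 2-chlorophenyl to benzyl on this aromatic carbon gives a 14-fold lower number from compound 3 to compound 4 (1.16 log units; beyond the scatter) and so shows that this position responds strongly to the group it carries. The two groups have the same heavy-atom count and the same kind of ring, so those counts alone do not set the number here. Nothing shown accounts for the size of this step.

The compounds shown leave open which part of the change matters: losing the chlorine or adding the methylene link. Plain phenyl or 2-chlorobenzyl on this carbon would separate the two.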